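A few compounds are considered here, and "the series" means these few. Any claim that something is new, unique, unknown or untested is made for them only; others in the source may bear on it.

Working notes on the series, measured in a physicochemical assay for solubility, measured as thermodynamic solubility, at pH 7.4; on this read-out higher numbers stand for higher solubility and lower numbers for lower solubility:

- Compound 1 `CC(=O)NC1CCN(c2nc(NC(c3ccccc3)c3ccccc3)c3c(n2)C(=O)N(C(C)C)C3)C1`: < 1000 nM (a limit)
- Compound 2 `CC(=O)N1CCN(c2nc(N[C@H](C)c3ccc(C)cc3)c3c(n2)C(=O)N(C(C)C)C3)CC1`: 260000 nM
- Compound 3 `CC(=O)N1CCN(c2nc(N[C@H](C)c3ccc(OC(F)(F)F)cc3)c3c(n2)C(=O)N(C(C)C)C3)CC1`: 61000 nM

Compound 2 holds the higher of the two actual numbers, and compound 3 is the nearest to it. Going by the values given here, compound 1 sits at the limit of < 1000 nM in this assay, at which 1 of the 3 values shown sits, but it differs from compound 2 in more than one place and so gives no clean step.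

Next is compound 4 `CC(=O)N1CCN(c2nc(NCc3cc4ccccc4cn3)c3c(n2)C(=O)N(C(C)C)C3)CC1`, which has (isoquinolin-3-yl)methyl in place of 1-(4-methylphenyl)ethyl on a nitrogen on an aromatic ring. The defined stereocentre of compound 2 is lost in this change.

Among the compounds with values here, only one measured step bears on this, and only loosely: a 4.3-fold lower number from compound 2 to compound 3 (0.63 log units; beyond the scatter). It is modest and beyond the scatter, and it changes a different part of the same group. With compound 2 at the top of the numbers, a downward move of similar or somewhat larger size is expected in this assay. The expected step is a 3.7-fold lower number from compound 2 to compound 4 (0.57 log units; beyond the scatter).

For compound 4 the estimated value is 70000 nM, with an expected range from 12000 nM to 220000 nM.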

Compound 4, solubility: 590000 nM
For compound 4 the middle estimate is 8.4-fold (0.93 log units) below the measured one, and the stated range ends below it.
By their numbers in this assay, from the lowest: compound 3; then compound 2; then compound 4. At a limit, below all of these: compound 1.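

In this assay this position can move the number upward as well as downward: the new change gives a 2.3-fold higher number from compound 2 to compound 4 (0.36 log units; beyond the scatter) while the earlier change within the same group gave a 4.3-fold lower number from compound 2 to compound 3 (0.63 log units; beyond the scatter). Compound 2 therefore no longer marks the top of the measured numbers, and replacing the whole group on this nitrogen reaches higher than compound 2 does. The change brings in a ring nitrogen and removes the defined stereocentre, but nothing measured here accounts for the step.

The compounds shown leave open whether the rise follows the ring nitrogen, the loss of the stereocentre or the larger (isoquinolin-3-yl)methyl group, as no pair separates these. Also open, on these data alone, is what an amine or a carboxylic acid on this group would do to the number.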